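The source may report more compounds than this note shows. Statements on the series, on what has been measured and on what is new or still open speak of the compounds shown alone.

Working notes on the series. The shared core is a cyclopropane carboxamide, seen in compound 1 `O=C(NCCCNC1CCCCC1)[C@H]1C[C@@H]1c1ccccc1`, compound 2 `CCN(CC)CCNC(=O)[C@H]1C[C@@H]1c1ccccc1` and compound 3 `CC(C)N(CCNC(=O)[C@H]1C[C@@H]1c1ccccc1)C(C)C`; the three differ only in the amine that sits on the chain carried by the amide nitrogen.

On an ADME assay (liver) for metabolic stability, with Liver microsome (Rattus norvegicus) as the target, using microsomes (on this read-out higher numbers stand for fast clearance and lower numbers for slow clearance), compound 1 gives 147 uL/min; "not determined" (no result reported); "not determined" (no result reported) (3 entries) as the one numerical result among its several entries, the others being reported without a number (the several entries of compound 1 in this assay, 147 uL/min; "not determined" (no result reported); "not determined" (no result reported) (3 entries)). Among the measured compounds shown here, compound 2 has no single number in this assay; its only entry is reported as "not determined" (no result reported), so where compound 2 stands in this assay is not known from the numbers, and no step from compound 2 can be sized.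

The change from compound 2 to compound 3 is diisopropylamino in place of diethylamino on a saturated chain carbon, two bonds along the chain from an amide-type nitrogen. For the measured compounds named here, with no measured step between any two compounds, there is no basis for expecting a step beyond the scatter in either direction in this assay; the only anchor is compound 1.

Going by the values given here, compound 3 is therefore estimated in this assay at 110 uL/min, with an expected range from 30 uL/min to 350 uL/min, resting on the single number of compound 1 at 147 uL/min; "not determined" (no result reported); "not determined" (no result reported) (3 entries).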

Compound 3, intrinsic clearance in a liver preparation (reported as CLH), per the amount of preparation that the assay uses in the Liver microsome assay: > 300 uL/min
Compound 3: a limit, no number (the forecaster's own chance of this, stated with the estimate: 10%); middle value at least 2.7-fold (0.43 log units) from the limit.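

No new step can be read between compound 2 and compound 3 in the Liver microsome assay, as compound 2 has no single number there. The entry of compound 3 is a limit, > 300 uL/min, not a number. In a physicochemical assay for acid dissociation, compound 2 gives 8.9 and compound 3 gives 9.7. The compounds shown leave open what diisopropylamino in place of diethylamino does in the Liver microsome assay.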